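Pyrazoline amides: cytotoxicity notes and compound 4 outlook

This account rests on a few compounds, and the source may have more. Where it says the series, first, only, none or still open, it means among the compounds named here.

Measured so far:
compound 1 `CC(=O)Oc1ccccc1C1CC(C)=NN1C(=O)CN1CCC(O)CC1`: 25600 nM
compound 2 `CC(=O)Oc1ccccc1C1CC(C)=NN1C(=O)CCl`: 3580 nM
compound 3 `CCC(=O)N1N=C(c2cc3ccccc3oc2=O)CC1c1ccccc1`: 4370 nM

In a functional assay on PC-3 cells (Homo sapiens) for cytotoxicity, read by MTT assay, with a stated time of 48 h (on this read-out higher numbers stand for weaker inhibition and lower numbers for stronger inhibition), compound 3 sits between its neighbours: compound 2 lies within the scatter of it, while compound 1 gives a higher number beyond the scatter. Compound 4 `CC1CCCN(CC(=O)N2N=C(c3cc4ccccc4oc3=O)CC2c2ccccc2)C1` differs from compound 3 by 3-methylpiperidin-1-yl in place of methyl on a saturated chain carbon bound to a carbonyl carbon. For the measured compounds named here, the only measured step at the same kind of position is a 7.2-fold lower number from compound 1 to compound 2 (0.85 log units; beyond the scatter), where chloro in place of 4-hydroxypiperidin-1-yl gave the lower number; compound 4 instead brings 3-methylpiperidin-1-yl in, though in place of methyl and on a different core, so the bearing is loose. A modestly higher number is therefore expected in this assay. Compound 4 is expected at 9000 nM, within 3000 nM to 30000 nM. The expected step is a 2.1-fold higher number from compound 3 to compound 4 (0.31 log units; beyond the scatter).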

Compound 4, half-maximal inhibitory concentration: 28300 nM
For compound 4 the middle estimate is 3.1-fold (0.50 log units) below the measured one; the range from low to high includes it.
By their numbers in this assay, from the lowest: compounds 2 and 3 (each within the scatter of the next); then compounds 1 and 4 (each within the scatter of the next).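

In this assay the change from methyl to 3-methylpiperidin-1-yl on a saturated chain carbon bound to a carbonyl carbon gives a 6.5-fold higher number from compound 3 to compound 4 (0.81 log units; beyond the scatter) on the shared core. Read with a 7.2-fold lower number from compound 1 to compound 2 (0.85 log units; beyond the scatter) on a different core, the member carrying a substituted piperidin-1-yl gives the higher number in both pairs, and none of the four compounds goes against this. Nothing available accounts for the step. Still open, as far as these compounds go, is whether the ring or its methyl carries the step, and how plain piperidin-1-yl, morpholin-4-yl or a dimethylamino group would read on the core of compound 3.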